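Working notes: methyl in place of chloro, compound 4

The source may report more compounds than this note shows. Statements on the series, on what has been measured and on what is new or still open speak of the compounds shown alone.

- compound 1 `N#C/C(=C\c1ccccc1OS(=O)(=O)c1ccc([N+](=O)[O-])cc1)C(=O)Nc1nnc(Cc2ccccc2)s1`: "not toxic" (no number reported)
- compound 2 `N#C/C(=C\c1ccccc1OS(=O)(=O)c1ccc([N+](=O)[O-])cc1)C(=O)Nc1nnc(Cc2cccc(F)c2)s1`: "not toxic" (no number reported)
- compound 3 `N#C/C(=C\c1ccccc1OS(=O)(=O)c1ccc([N+](=O)[O-])cc1)C(=O)Nc1nnc(Cc2ccc(Cl)cc2)s1`: 19%

For the measured compounds named here, in an ADME assay on HEK-293T cells (Homo sapiens) for inhibition, read by CCK-8 assay, with a stated time of 48 h, tested at 20 uM (a higher number here means more inhibition of growth at the concentration tested, a lower number less inhibition of growth), compound 3 gives 19%, and this is the only number so far. Compound 1 and compound 2 carry a verbal entry without a number, so compound 3 cannot be ranked against either of them. Going by the values given here, the series therefore offers one numerical reference point and no measured step between compounds.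

The next compound is compound 4 `Cc1ccc(Cc2nnc(NC(=O)/C(C#N)=C/c3ccccc3OS(=O)(=O)c3ccc([N+](=O)[O-])cc3)s2)cc1`. It keeps the shared core of compound 3 and changes one group: methyl in place of chloro on an aromatic carbon. In words, this is methyl in place of chloro on an aromatic carbon, para to a large group, or 4-chlorobenzyl to 4-methylbenzyl.

Among the compounds with values here, no measured step shows what this exchange does in this assay, so no direction is favoured. The expectation rests on compound 3 at 19% alone, and the expected change is none beyond the usual scatter. The estimated step of a number 2 percentage points lower from compound 3 to compound 4 (within the scatter) is correspondingly small. A verbal entry without a number also remains possible, as seen for compound 1 and compound 2.

In this assay the estimated value for compound 4 is 17%, with an expected range from 5% to 32%.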

Compound 4, percent growth inhibition at one concentration: 9%
The estimate for compound 4 lay 8 percentage points above the measured number; measured number inside the range.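

In this assay, for the compounds shown here, the exchange of 4-chlorobenzyl to 4-methylbenzyl gives a number 10 percentage points lower from compound 3 to compound 4 (within the scatter), the first step that can be read as a number. At this place on the aromatic ring, para to a large group, chloro and methyl therefore cannot be told apart in this read-out, and the series now has two numerical reference points instead of one, with compound 3 and compound 4 both reported as numbers and close together within the usual spread of repeat measurements. No measured property of either group accompanies this pair, and nothing here accounts for the size of the step.

Steps to compound 1 and compound 2 cannot be read, as both carry only a verbal entry, so how the two numbers relate to those compounds remains unknown. Also open, as far as these compounds go, is whether a group of a different kind at the same place, such as an amine, a carboxylic acid or a longer chain, would give a step beyond the scatter in this assay, or whether growth inhibition at the tested concentration stays insensitive to this position.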